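The compounds below may be only part of what the source reports. "The series", "measured", "known", "first", "only" and "open" are said of these compounds alone.

Measured in an assay on membranes from CHO cells for displacement of a labelled ligand from adenosine receptor A1 (Homo sapiens), read by scintillation counting, with a stated time of 60 min, tested at 1 uM; a lower number here means less inhibition, a higher number more inhibition at the concentration tested (going by the name of the read-out):
compound 1 `CC1=C(C(=O)OCC(C)C)C(c2cccs2)NC(=O)N1C`, 9%
compound 2 `CCOC(=O)C1=C(C)N(C)C(=O)NC1c1ccsc1`, 32%
compound 3 `CCCOC(=O)C1=C(C)N(C)C(=O)NC1c1ccsc1`, 2%

Compound 3 gives the lowest of the three numbers in this assay, though its gap to compound 1 lies within the scatter; only the gap to compound 2 lies beyond it. Compound 4 `CC1=C(C(=O)OCC(C)C)C(c2ccsc2)NC(=O)N1C` is not yet measured. It differs from compound 3 by methyl in place of hydrogen on a saturated chain carbon bound to two saturated chain carbons. Going by the values given here, the one measured step of the same kind, a methyl in place of hydrogen on a saturated chain carbon, is a number 30 percentage points lower from compound 2 to compound 3 (beyond the scatter), a modest drop. Compound 3 already sits near the bottom of the read-out, so no comparable drop is available; the number for compound 4 is expected to stay roughly where compound 3 stands, a step of a number 3 percentage points higher from compound 3 to compound 4 (within the scatter). For compound 4 the estimate is 5%, with a range of -5% to 15%.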

Compound 4, a percentage reported as inhibition, at one concentration (the size of the read-out at that concentration, not a potency): 8%
For compound 4 the middle estimate is 3 percentage points below the measured one, and the stated range covers the measured number.
By their numbers in this assay, from the lowest: compounds 3, 4 and 1 (each within the scatter of the next); then compound 2.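

In this assay, propyl to isobutyl gives a number 6 percentage points higher from compound 3 to compound 4 (within the scatter), so branching at this saturated chain carbon leaves the read-out in place, while isopropyl in place of methyl gives a number 24 percentage points lower from compound 2 to compound 4 (beyond the scatter), a drop of the same order as the one already seen from adding a single methyl. Thiophen-3-yl in place of thiophen-2-yl on a saturated ring carbon gives a number 1 percentage points lower from compound 1 to compound 4 (within the scatter), so with this chain the two thiophenes are not told apart. Nothing available explains these steps.

Open, from the compounds shown here alone, is whether any group other than these alkyl chains, such as a chain ending in an amine or a carboxylic acid, brings the read-out back towards that of compound 2. Also open, going by these compounds, is whether the two thiophenes are told apart with a shorter chain.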